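This account rests on a few compounds, and the source may have more. Where it says the series, first, only, none or still open, it means among the compounds named here.

Series notes, step from compound 3 to compound 4.

Of the compounds shown here, three have numbers so far. Compound 1 `CC[C@H](C)[C@H](NC(=O)CN(c1nc(Cl)nc2[nH]cnc12)C1CC1)C(=O)O` gives 30.3% in a functional assay on the whole organism (Tail, strain ICR) with Mus musculus as the target, in the tail flick test, with a stated time of 30 min, at a dose of 25 umol/kg by the oral route; a lower number here means a weaker effect, a higher number a stronger effect of the compound at the dose given. Compound 2 `O=C(CN(c1nc(Cl)nc2[nH]cnc12)C1CC1)N[C@@H](CCC(=O)OCc1ccccc1)C(=O)OCc1ccccc1` gives 52.8% in this assay. Compound 3 `C[C@@H](O)[C@H](NC(=O)CN(c1ncnc2c1ncn2C1CCCCO1)C1CC1)C(=O)OCc1ccccc1` gives 23.6% in this assay, the lowest of the three numbers; its nearest neighbour is compound 1, which lies within the scatter of compound 3, while compound 2 stands beyond the scatter above it. Within the data shown here, compounds 1 and 2 carry a different core from compound 3, so no pair differing in a single place is present, and no measured step is available to lean on.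

Compound 4 `CC(C)C[C@H](NC(=O)CN(c1ncnc2c1ncn2C1CCCCO1)C1CC1)C(=O)OCc1ccccc1` is not yet measured. It differs from compound 3 by isobutyl in place of 1-hydroxyethyl on a saturated chain carbon bound to an amide-type nitrogen and a carbonyl carbon. Among the measured compounds shown here, with no comparable step on record, the expected step in this assay is small, and it is not expected to exceed the scatter in either direction with any confidence; if anything a slight rise is expected. On that basis the step from compound 3 is estimated at a number 6.4 percentage points higher from compound 3 to compound 4 (within the scatter). Compound 4 is therefore expected to give about 30% in this assay, within a range from 15% to 50%.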

Compound 4, a percentage reported as activity, at one dose (the size of the read-out at that dose, not a potency): 26.2%
For compound 4 the middle estimate is 3.8 percentage points above the measured one, within the range that was stated.
By their numbers in this assay, from the lowest: compounds 3, 4 and 1 (each within the scatter of the next); then compound 2.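

Among these compounds, the first one-place comparison reads, in this assay, as a number 2.6 percentage points higher from compound 3 to compound 4 (within the scatter), for isobutyl in place of 1-hydroxyethyl on a saturated chain carbon bound to an amide-type nitrogen and a carbonyl carbon. At this position, then, a group with a hydrogen-bond donor and a hydrogen-bond acceptor and a group with neither, all carbon, give read-outs that cannot be told apart, so this exchange on its own gives no measurable handle on the activity. No measurement at hand bears on why the step has this size.

The compounds shown leave open whether an amine, a carboxylic acid or a phenyl ring on this same carbon would produce a step beyond the scatter, since only two groups have been compared here and a single pair sets no trend. Among the compounds shown here, also open is whether the exchange of 1-hydroxyethyl for isobutyl would read the same way in this assay on the core of compound 1, where no such pair is available.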